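Shortening the amine substituent on a tricyclic core

The source may report more compounds than this note shows. Statements on the series, on what has been measured and on what is new or still open speak of the compounds shown alone.

A small set of compounds sharing one core was tested in a functional assay on EL4 cells (Mus musculus) for inhibition, tested at 100 uM; on this read-out lower numbers stand for less inhibition and higher numbers for more inhibition at the one concentration tested (going by the name of the read-out). Compound 1 `c1ccc(Nc2[nH]ccc3ncnc2-3)cc1` carries a phenyl group on the amine nitrogen and in this assay gives 26%. Compound 3 `CCCCCCNc1[nH]ccc2ncnc1-2` carries a hexyl chain there and reaches 100%. Compound 2 `CNc1[nH]ccc2ncnc1-2` carries only a methyl group on that nitrogen. For compound 2 this assay reports only a limit, < 5%, so its exact position is not known; this is the limit of < 5% in this assay, at which 1 of the 3 values shown sits.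

The step to compound 4 `Nc1[nH]ccc2ncnc1-2` is hydrogen in place of methyl on a nitrogen on an aromatic ring, the methylamino group becoming an amino group. Within the data shown here, only one measured step bears on it: a number at least 95 percentage points higher from compound 2 to compound 3 (beyond the scatter), where a longer chain on that nitrogen brought a large rise. The change to compound 4 runs the other way, removing carbon rather than adding it, so no rise beyond the scatter is expected and the compound is expected to remain near the limit. Compound 4 is therefore estimated at 3%, within 0% to 12%, meaning an expected step that the limit leaves unreadable from compound 2 to compound 4.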

Compound 4, a percentage reported as inhibition, at one concentration (the size of the read-out at that concentration, not a potency): < 5%
Compound 4: no number, only a limit; the forecaster's own chance of this, stated with the estimate: 70%; the middle value lies beyond the limit too.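

No step can be read between compound 2 and compound 4, because each of them gives only a limit: the limit of < 5% in this assay, at which 2 of the 4 values shown sit.

The compounds shown leave open whether methyl or hydrogen on that nitrogen makes any difference in this assay.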